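A few compounds are considered here, and "the series" means these few. Any claim that something is new, unique, unknown or untested is made for them only; others in the source may bear on it.

Working notes on the series in a functional assay on HeLa cells (Homo sapiens) for inhibition, with a stated time of 72 h; on this read-out higher numbers stand for weaker inhibition and lower numbers for stronger inhibition. Of the compounds shown here, three sharing one core have been measured so far: compound 1 (`O=c1[nH]c(=O)n([C@H]2C[C@H](O)[C@@H](CO)O2)cc1COc1cccc(Br)c1`) gives 15000 nM, compound 2 (`COc1ccc(OCc2cn([C@H]3C[C@H](O)[C@@H](CO)O3)c(=O)[nH]c2=O)cc1`) gives 200000 nM, and compound 3 (`O=c1[nH]c(=O)n([C@H]2C[C@H](O)[C@@H](CO)O2)cc1COc1ccc([N+](=O)[O-])cc1`) gives 250000 nM. Compound 3 stands at the high end of these numbers, and the furthest value lies at a 17-fold higher number from compound 1 to compound 3 (1.22 log units; beyond the scatter).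

Next is compound 4 (`O=c1[nH]c(=O)n([C@H]2C[C@H](O)[C@@H](CO)O2)cc1COc1ccccc1`), which carries hydrogen in place of nitro on an aromatic carbon, para to a large group: hydrogen in place of nitro on an aromatic carbon. Within the data shown here, no measured step removes a substituent outright, so the evidence is indirect. The closest comparison is the exchange of methoxy for nitro, a 1.3-fold higher number from compound 2 to compound 3 (0.10 log units; within the scatter), which leaves the two values within the scatter. The large moves, a 13-fold higher number from compound 1 to compound 2 (1.12 log units; beyond the scatter) and a 17-fold higher number from compound 1 to compound 3 (1.22 log units; beyond the scatter), both start from the 3-bromophenyl of compound 1, a group that compound 4 does not carry, so they bear on this change only weakly.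

In this assay, no step beyond the scatter is therefore expected, with only a slight lean towards a lower number. The expected change is a 1.5-fold lower number from compound 3 to compound 4 (0.17 log units; within the scatter). For compound 4 the estimated value is 170000 nM, with an expected range from 50000 nM to 450000 nM.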

Compound 4, half-maximal inhibitory concentration: 200000 nM
The estimate for compound 4 lay 1.2-fold (0.07 log units) below the measured number, and the stated range covers the measured number.
By their numbers in this assay, from the lowest: compound 1; then compounds 2, 4 and 3 (each within the scatter of the next).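

In this assay, hydrogen in place of nitro gives a 1.3-fold lower number from compound 3 to compound 4 (0.10 log units; within the scatter), and hydrogen in place of methoxy gives no change at the digits printed from compound 2 to compound 4 (within the scatter), so on an aromatic carbon para to a large group neither nitro nor methoxy separates from plain hydrogen in this series. Hydrogen in place of bromo gives a 13-fold higher number from compound 1 to compound 4 (1.12 log units; beyond the scatter), which gives the 3-bromophenyl group a direct comparison with the unsubstituted phenyl and leaves compound 1 as the only one of the four compounds set apart by a step beyond the scatter. No measurement at hand accounts for either the flat steps or the large one.

The compounds shown do not separate the bromo group itself from the place it occupies, since a 4-bromophenyl or a 3-nitrophenyl group on the same core would be needed to tell these apart. From the compounds shown here alone, it also remains open whether a chloro group on the same ring would follow bromo, and whether an amine or a carboxylic acid on the aromatic carbon para to a large group would stay level with hydrogen, as nitro and methoxy do.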